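Urea series: solubility expectation for a tolyl analogue

The compounds below may be only part of what the source reports. "The series", "measured", "known", "first", "only" and "open" are said of these compounds alone.

Measured compounds:
compound 1 `Cc1cc(NC(=O)Nc2ccc(C)c(Cl)c2)c2ccccc2n1`, 300 nM
compound 2 `COc1ccc(NC(=O)Nc2cc(C)nc3ccccc23)cc1`, 19800 nM
compound 3 `Cc1cc(NC(=O)Nc2ncccc2C)c2ccccc2n1`, 1300 nM

In a physicochemical assay for solubility, at pH 7.4 (a lower number here means a less soluble compound, a higher number a more soluble compound), compound 3 stands second highest of the three numbers. Its nearest neighbour is compound 1, which gives 300 nM, a lower number beyond the scatter; furthest is compound 2, which gives 19800 nM, a higher number also beyond the scatter. Compound 4 `Cc1ccc(NC(=O)Nc2cc(C)nc3ccccc23)cc1` is not yet measured. It differs from compound 3 in one place: 4-methylphenyl in place of 3-methylpyridin-2-yl on an amide-type nitrogen. The step expected in this assay is downward and of moderate size, a 2.6-fold lower number from compound 3 to compound 4 (0.41 log units; beyond the scatter), because compound 1, which also carries a six-membered aromatic ring of carbon only on this nitrogen, gives 300 nM. Compound 4 is therefore estimated at 500 nM, with a range of 150 nM to 1800 nM.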

Compound 4, solubility: 1300 nM
Compound 4: middle estimate off by 2.6-fold (0.41 log units), on the low side, within the range that was stated.
By their numbers in this assay, from the lowest: compound 1; then compounds 3 and 4 (each within the scatter of the next); then compound 2.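

In this assay the change to 4-methylphenyl from 3-methylpyridin-2-yl on the amide-type nitrogen shows no change at the digits printed from compound 3 to compound 4 (within the scatter) and so a six-membered aromatic ring of carbon only at this place does not on its own set the number. The larger steps go with other changes: a 4.3-fold higher number from compound 1 to compound 4 (0.64 log units; beyond the scatter) comes with hydrogen in place of chloro on an aromatic carbon, and a 15-fold lower number from compound 2 to compound 4 (1.18 log units; beyond the scatter) comes with methyl in place of methoxy on an aromatic carbon. As far as these compounds go, whether an amine or a carboxylic acid on this ring would move the number stays open. No supporting measurement speaks to what lies behind these steps.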